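Replacing a chlorophenyl with a pyridyl: expected cytotoxicity

This account rests on a few compounds, and the source may have more. Where it says the series, first, only, none or still open, it means among the compounds named here.

Compound 2 `Cc1nc(-c2cccnc2)sc1-c1nnc(-c2ccc(Cl)cc2)o1` was tested in an ADME assay on THP-1 cells (Homo sapiens) for cytotoxicity, read by MTT assay; on this read-out higher numbers stand for lower toxicity in this test and lower numbers for higher toxicity in this test. In this assay compound 2 gives > 100 ug/mL, which is a limit of the assay and not a measured number. Two close relatives were run in the same test. Compound 1 `Cc1nc(-c2cccnc2)sc1-c1nnc(-c2ccc(Br)cc2)o1` differs from compound 2 only by bromo where compound 2 has chloro on an aromatic carbon. In this assay compound 1 gives > 100 ug/mL, again a limit. Compound 3 `Cc1nc(-c2cccnc2)sc1-c1nnc(-c2ccccc2[N+](=O)[O-])o1` is the third member of the group. In this assay compound 3 gives > 100 ug/mL, also a limit. Among the compounds with values here, the only step that can be drawn between neighbours is a step that the two limits leave unreadable from compound 1 to compound 2, so its size stays unknown. Within the data shown here, the evidence summary the limit of > 100 ug/mL in this assay, at which 3 of the 3 values shown sit, shows that every value so far sits at the same limit.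

Compound 4 `Cc1nc(-c2cccnc2)sc1-c1nnc(-c2cccnc2)o1` is the compound still to be measured. Its change from compound 2 is pyridin-3-yl in place of 4-chlorophenyl on an aromatic carbon. Among the measured compounds shown here, no measured step bears on this exchange, and the single step available is unreadable. Because of the limit of > 100 ug/mL in this assay, at which 3 of the 3 values shown sit, no step beyond the scatter is expected in this assay. For compound 4 the estimate in this assay is 150 ug/mL, with a range from 70 ug/mL to 400 ug/mL. This estimate implies an expected step that the limit leaves unreadable from compound 2 to compound 4, most likely reported again as a limit.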

Compound 4, half-maximal cytotoxic concentration: > 100 ug/mL
Compound 4 ended at the assay's limit; the forecaster's own chance of this, stated with the estimate: 80%; the middle value is on the limit's open side.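

Compound 4 gives a limit again in this assay, and not a measured number, so the steps to it from compound 2 and from compound 1 cannot be read; all the values share one limit: the limit of > 100 ug/mL in this assay, at which 4 of the 4 values shown sit.

The compounds shown leave open how far each lies beyond that limit, and so whether pyridin-3-yl in place of 4-chlorophenyl makes any difference to cytotoxicity.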